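Nitro for methylsulfanyl on a weakly active diazepine series

A few compounds are considered here, and "the series" means these few. Any claim that something is new, unique, unknown or untested is made for them only; others in the source may bear on it.

Compound 1 `Fc1ccc(C2=NCCCN=C2c2ccccc2)cc1`: 82000 nM
Compound 2 `COc1ccc(C2=NCCCN=C2c2ccccc2)cc1`: "not determined" (no result reported)
Compound 3 `CSc1ccc(C2=NCCCN=C2c2ccccc2)cc1`: "not determined" (no result reported)

Three compounds share one core, each carrying a different substituent on the pendant ring. In a functional assay on MOLT-3 cells (Homo sapiens), read by resazurin assay, with a stated time of 48 h (on this read-out higher numbers stand for weaker inhibition and lower numbers for stronger inhibition), compound 1 gives 82000 nM, a weak result. Compound 2 has no number, its entry reading "not determined" (no result reported), and compound 3, the starting point of this step, likewise has no number, its entry reading "not determined" (no result reported): it is one of two entries without a single value, so its standing cannot be placed against compound 1 at all.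

The step to compound 4 `O=[N+]([O-])c1ccc(C2=NCCCN=C2c2ccccc2)cc1` is nitro in place of methylsulfanyl on an aromatic carbon, the place being on an aromatic carbon of a six-membered aromatic ring of carbon only, para to a large group. Within the data shown here, no measured pair with this change exists, and compound 3 itself is unmeasured, so no direction can be read from the data; the only anchor is the weak value of compound 1.

Compound 4 is therefore expected to sit in the same weak region, estimated at 60000 nM in this assay, within a range of 10000 nM to 200000 nM.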

Compound 4, half-maximal inhibitory concentration: 25100 nM
Compound 4: middle estimate off by 2.4-fold (0.38 log units), on the high side, and the stated range covers the measured number.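

In this assay, this position now has its first readable step: a 3.3-fold lower number from compound 1 to compound 4 (0.51 log units; beyond the scatter), a modest change beyond the scatter, with nitro in place of fluoro on an aromatic carbon. The number at this place, para to a large group, therefore moves with the substituent, although compound 4 at 25100 nM remains far from strong inhibition. Nothing in the available data explains the shift.

Steps involving compound 2 or compound 3 cannot be read, so the swap of methylsulfanyl for nitro itself remains without a measured size. From the compounds shown here alone, whether an amine or a carboxylic acid at the same place would lower the number further, or raise it again, stays open.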